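Carboxy in place of methyl on the pyridine of compound 1

The source may hold more compounds than are shown below. What is called first, only, known or untested is meant among the compounds shown, and "the series" means these compounds.

Measured compounds:
compound 1, `Cc1cccc(OC(c2ccc(C(F)(F)F)cc2)C2CCN(C(C)CCNC(=O)c3c(Cl)cncc3Cl)CC2)n1`: 6700 nM
compound 2, `CCO/N=C(/c1ccc(Br)cc1)C1CCN(C(CC)CCNC(=O)c2c(C)cc[n+]([O-])c2C)CC1`: > 177000 nM
compound 3, `CCO/N=C(/c1ccc(Br)cc1)C1CCN(C(C)CNC(=O)c2c(C)cc[n+]([O-])c2C)CC1`: 182000 nM

Of the compounds shown here, three have been tested in an ADME assay on PBMC cells (Homo sapiens) for cytotoxicity; on this read-out lower numbers stand for higher toxicity in this test and higher numbers for lower toxicity in this test. Compound 1, `Cc1cccc(OC(c2ccc(C(F)(F)F)cc2)C2CCN(C(C)CCNC(=O)c3c(Cl)cncc3Cl)CC2)n1`, gives 6700 nM, the lowest of the two numbers obtained. Compound 3 gives 182000 nM, which lies well beyond the scatter above the number for compound 1. For compound 2 the assay reports only a limit, > 177000 nM, not a number. This is the limit described as the limit of > 177000 nM in this assay, at which 1 of the 3 values shown sits.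

The account now turns to compound 4, `CC(CCNC(=O)c1c(Cl)cncc1Cl)N1CCC(C(Oc2cccc(C(=O)O)n2)c2ccc(C(F)(F)F)cc2)CC1`, which has not yet been tested in this assay. It differs from compound 1 in a single place: carboxy in place of methyl on an aromatic carbon. For the measured compounds named here, no pair of measured compounds differs in one place, so no measured step guides this change. The expectation is for a moderate step toward a higher number, with the scatter of repeated measurements leaving room for no change at all. The estimated step from compound 1 to compound 4 is a 2.7-fold higher number from compound 1 to compound 4 (0.43 log units; beyond the scatter). In this assay compound 4 is expected to give about 18000 nM, with a likely range from 6000 nM to 60000 nM.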

Compound 4, half-maximal cytotoxic concentration: 28700 nM
For compound 4 the middle estimate is 1.6-fold (0.20 log units) below the measured one; the measured number falls inside the stated range.
By their numbers in this assay, from the lowest: compound 1; then compound 4; then compound 3.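

For the compounds shown here, the change from 6-methylpyridin-2-yl to 6-carboxypyridin-2-yl gives the first step between measured compounds that differ in one place: in this assay, the result is a 4.3-fold higher number from compound 1 to compound 4 (0.63 log units; beyond the scatter). This modest step, which lies beyond the scatter, shows that at this aromatic carbon next to the ring nitrogen, carboxy in place of methyl moves the read-out toward lower toxicity in this test, not higher. Nothing measured here gives a reason for the size or direction of this step.

The compounds shown leave open whether a methyl ester, a primary amide or a hydroxymethyl group on this same carbon would move the number as carboxy does, and whether carboxy on another carbon of this ring would have the same effect. They also leave open whether the step would keep its size with bromo in place of trifluoromethyl, since this single pair is the only one that speaks to the change.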